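A Benzimidazole Amine Replaces the Pyrazole Amine

The compounds below may be only part of what the source reports. "The series", "measured", "known", "first", "only" and "open" are said of these compounds alone.

Compound 1 `Cc1ccc(CNC(=O)c2cccc(C(C)Oc3ccnc(Nc4cnn(C)c4)c3)c2)cc1`: 7700 nM
Compound 2 `Cc1ccc(CNC(=O)c2cccc(C(C)Oc3ccnc(Nc4cn(C)nc4C)c3)c2)cc1`: 13400 nM
Compound 3 `Cc1ccc(CNC(=O)c2cccc(C(C)Oc3ccnc(Nc4cnn(CC(C)(C)O)c4)c3)c2)cc1`: > 100000 nM (a limit of the assay)

In a functional assay on NCI-H3122 cells (Homo sapiens) for antiproliferative activity, read by MTT assay, with a stated time of 48 h (on this read-out lower numbers stand for stronger inhibition and higher numbers for weaker inhibition), compound 1 gives 7700 nM and compound 2 gives 13400 nM; the step of a 1.7-fold higher number from compound 1 to compound 2 (0.24 log units; within the scatter) stays within the scatter. For compound 3 the assay reports only a limit, > 100000 nM (the limit of > 100000 nM in this assay, at which 1 of the 3 values shown sits). The steps of an at least 12-fold higher number from compound 1 to compound 3 (1.11 log units; beyond the scatter) and an at least 7.4-fold higher number from compound 2 to compound 3 (0.87 log units; beyond the scatter) both lie beyond the scatter, so compound 3 is the weakest of the three and stands at the limit.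

Compound 4 `Cc1ccc(CNC(=O)c2cccc(C(C)Oc3ccnc(Nc4nc5ccccc5[nH]4)c3)c2)cc1` differs from compound 3 by 1H-benzimidazol-2-yl in place of 1-(2-hydroxy-2-methylpropyl)-1H-pyrazol-4-yl on a nitrogen on an aromatic ring. For the measured compounds named here, none of the measured steps covers an exchange of this kind: the two steps that lead to compound 3 change a group on a saturated chain carbon bound to an aromatic nitrogen or on an aromatic carbon, while the ring itself stays in place. Going by the values given here, the step to compound 4 therefore has no direct precedent, and the limit on compound 3 leaves its starting point open. Given this, the step of an at least 4.0-fold lower number from compound 3 to compound 4 (0.60 log units; beyond the scatter) is expected to run toward a lower number, though its size is very uncertain. Compound 4 is estimated at 25000 nM, within a range from 4000 nM to 150000 nM.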

Compound 4, half-maximal inhibitory concentration: 9400 nM
Compound 4: middle estimate off by 2.7-fold (0.42 log units), on the high side, within the range that was stated.
By their numbers in this assay, from the lowest: compounds 1, 4 and 2 (each within the scatter of the next). At a limit, above all of these: compound 3.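

On the nitrogen on an aromatic ring, 1H-benzimidazol-2-yl takes the place of 1-methyl-1H-pyrazol-4-yl and 1,3-dimethyl-1H-pyrazol-4-yl in this assay with no change beyond the scatter: the steps read a 1.2-fold higher number from compound 1 to compound 4 (0.09 log units; within the scatter) and a 1.4-fold lower number from compound 2 to compound 4 (0.15 log units; within the scatter). The earlier compounds shown here varied only the groups carried by a pyrazole ring, whereas this result shows that the ring itself can give way to a group with an added six-membered aromatic ring of carbon only and still stay level with compound 1 and compound 2. Against compound 3 the same position shows an at least 10-fold lower number from compound 3 to compound 4 (1.02 log units; beyond the scatter), and this step is only a bound, set by the limit on compound 3: the limit of > 100000 nM in this assay, at which 1 of the 4 values shown sits.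

The compounds shown leave open whether a substituent on the six-membered ring of the 1H-benzimidazol-2-yl group, such as a fluorine, a methoxy or a dimethylamino group, or a methyl on its ring nitrogen, would move the number beyond the scatter. They also leave open whether the weak result of compound 3 goes with the hydroxyl of its chain, which a plain isobutyl group on the pyrazole could test.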